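The source may report more compounds than this note shows. Statements on the series, on what has been measured and on what is new or still open speak of the compounds shown alone.

In a functional assay on MCF7 cells (Homo sapiens) for antiproliferative activity, read by MTT assay, with a stated time of 48 h (on this read-out higher numbers stand for weaker inhibition and lower numbers for stronger inhibition), compound 2 `O=C(/C=C/c1cccc(NC(=O)c2ccccc2Br)c1)c1nc2ccccc2[nH]1` gives 4520 nM, and compound 1 `O=C(Nc1cccc(/C=C/C(=O)c2nc3ccccc3[nH]2)c1)c1ccc(Cl)cc1` gives 8410 nM; the step of a 1.9-fold lower number from compound 1 to compound 2 (0.27 log units; within the scatter) does not separate the two beyond the scatter, so neither stands apart from the other. Compound 3 `O=C(/C=C/c1cccc(NS(=O)(=O)c2cccc(Cl)c2)c1)c1nc2ccccc2[nH]1` has not yet been measured. It differs from compound 2 in one place: (3-chlorophenyl)sulfonyl in place of (2-bromophenyl)carbonyl on a nitrogen on an aromatic ring. Going by the values given here, no measured step bears directly on this exchange; the only step known changed a different group and stayed within the scatter. For this assay, compound 3 is therefore expected to move little, about a 1.1-fold higher number from compound 2 to compound 3 (0.04 log units; within the scatter). The estimate for compound 3 is 5000 nM, within a range from 1500 nM to 16000 nM.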

Compound 3, half-maximal inhibitory concentration: 4160 nM
Compound 3: middle estimate off by 1.2-fold (0.08 log units), on the high side; the measured number falls inside the stated range.
By their numbers in this assay, from the lowest: compounds 3, 2 and 1 (each within the scatter of the next, the first and the last beyond it).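

At this nitrogen on an aromatic ring, a sulfonyl link can stand in for a carbonyl link without a clear loss: in this assay, (3-chlorophenyl)sulfonyl in place of (2-bromophenyl)carbonyl gives a 1.1-fold lower number from compound 2 to compound 3 (0.04 log units; within the scatter). Set against (4-chlorophenyl)carbonyl, the same group gives a 2.0-fold lower number from compound 1 to compound 3 (0.31 log units; beyond the scatter), a modest step just past the scatter. Nothing measured here explains either step. Still open, as far as these compounds go, is whether this nitrogen tolerates a group without a ring, such as a methylsulfonyl, or a urea in place of the amide. From the compounds shown here alone, the effect of moving the chlorine around the ring also remains unknown.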